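The source may report more compounds than this note shows. Statements on the series, on what has been measured and on what is new or still open speak of the compounds shown alone.

Compound 1 `Clc1ccc(/C=N/c2sc3c(c2-c2nc4ccccc4s2)CCCC3)cc1`: in an ADME assay on cells (Rhabdomyosarcoma cell, Homo sapiens) for cytotoxicity, read by MTT assay, with a stated time of 72 h (a higher number here means that more compound is tolerated, a lower number that less compound is tolerated), compound 1 gives 367 ug/mL. Compound 2 `Clc1ccc(/C=N/c2sc3c(c2-c2nc4ccccc4s2)CCCC3)c(Cl)c1`: in this assay compound 2 gives 56.6 ug/mL.

Compound 2 stands lowest of the two numbers; compound 1 shows the higher number. Among the compounds with values here, the single measured step, a 6.5-fold lower number from compound 1 to compound 2 (0.81 log units; beyond the scatter), followed the addition of a chlorine. Compound 3 `Fc1ccccc1/C=N/c1sc2c(c1-c1nc3ccccc3s1)CCCC2` is not yet measured; it differs from compound 2 by 2-fluorophenyl in place of 2,4-dichlorophenyl on a carbon with a double bond to nitrogen. Both chlorines leave, and one fluorine enters. As far as these compounds go, since the step of a 6.5-fold lower number from compound 1 to compound 2 (0.81 log units; beyond the scatter) followed one chlorine entering, a move back toward the number of compound 1 is expected, though the fluorine is untested here. Compound 3 is therefore estimated at 250 ug/mL, expected between 90 ug/mL and 500 ug/mL. This corresponds to an expected step of a 4.4-fold higher number from compound 2 to compound 3 (0.65 log units; beyond the scatter).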

Compound 3, half-maximal cytotoxic concentration: 319 ug/mL
Estimate against measurement, compound 3: 1.3-fold (0.11 log units) below, and the stated range covers the measured number.
By their numbers in this assay, from the lowest: compound 2; then compounds 3 and 1 (each within the scatter of the next).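

In this assay, replacing 2,4-dichlorophenyl with 2-fluorophenyl gives a 5.6-fold higher number from compound 2 to compound 3 (0.75 log units; beyond the scatter), so the lower number of compound 2 does not extend to every halogen-bearing phenyl group at this position. Replacing 4-chlorophenyl with 2-fluorophenyl gives a 1.2-fold lower number from compound 1 to compound 3 (0.06 log units; within the scatter), so among these three compounds only the 2,4-dichlorophenyl group stands apart. No evidence bearing on the cause of these differences is available. As far as these compounds go, it remains open whether the lower number of compound 2 depends on having both chlorines. From the compounds shown here alone, the response to a phenyl group carrying an amine or a methoxy group also remains open.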